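A few compounds are considered here, and "the series" means these few. Any claim that something is new, unique, unknown or untested is made for them only; others in the source may bear on it.

Of the compounds shown here, two have so far been measured in a functional assay on IGROV-1 cells (Homo sapiens) for inhibition, read by sulforhodamine B assay, with a stated time of 48 h; a lower number here means a stronger inhibitor of growth, a higher number a weaker inhibitor of growth. Compound 1 `O=C(Nc1cccc(-n2cc(-c3ccncc3)c(-c3ccc(Cl)c(O)c3)n2)c1)Nc1cccc(C(F)(F)F)c1` gives only a limit of the assay there, > 32500 nM. Compound 2 `COc1cc(-c2nn(-c3cccc(NC(=O)c4cccc(C(F)(F)F)c4)c3)cc2-c2ccncc2)ccc1Cl` likewise returns only a limit, > 50000 nM. For the measured compounds named here, compound 2 therefore stands at a limit rather than at a number, and the one other value shown is a limit too, as recorded in the limit of > 32500 nM in this assay, at which 1 of the 2 values shown sits, and (the limit of > 50000 nM in this assay, at which 1 of the 2 values shown sits). Going by the values given here, no step between measured compounds that differ in one place is available.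

Compound 3 `COc1cc(-c2nn(-c3cccc(NC(=O)Nc4ccc(Cl)c(C(F)(F)F)c4)c3)cc2-c2ccncc2)ccc1Cl` differs from compound 2 by (4-chloro-3-(trifluoromethyl)phenyl)amino in place of 3-(trifluoromethyl)phenyl on a carbonyl carbon. Among the compounds with values here, since compound 2 gives only the limit > 50000 nM, no measured step guides the expectation. Compound 3 is expected to give about 40000 nM in this assay, within 8000 nM to 100000 nM. The expected step of an at least 1.2-fold lower number from compound 2 to compound 3 (0.09 log units; that floor lies within the scatter) is none beyond the usual scatter, and a limit rather than a number is the likelier outcome.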

Compound 3, concentration for total growth inhibition: 4220 nM
Compound 3: the middle estimate sits 9.5-fold (0.98 log units) above what was measured, outside the stated range (below it).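

In this assay compound 3 is the only compound shown that returns a number rather than a limit of the assay, which makes this place on a carbonyl carbon the first to show a measurable response. Putting (4-chloro-3-(trifluoromethyl)phenyl)amino in place of 3-(trifluoromethyl)phenyl there gives an at least 11-fold lower number from compound 2 to compound 3 (1.07 log units; beyond the scatter). That size is a floor and not a measured gap, since compound 2 stands only at a limit: the limit of > 50000 nM in this assay, at which 1 of the 3 values shown sits.

The entering group brings a chlorine and an amino nitrogen together, so the compounds shown do not tell which of the two carries the step, nor why it occurs. From the compounds shown here alone, whether a bromine atom or a nitrile in place of that chlorine, or a methylene in place of that amino nitrogen, would keep the step also stays open.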